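Swapping the Azetidine Ring on the Shared Core

The compounds below may be only part of what the source reports. "The series", "measured", "known", "first", "only" and "open" are said of these compounds alone.

Compound 1 `O=C(CCc1ccc(C(F)(F)F)cc1)Nc1ccc2nc(N3CCC3)ccc2c1` is the reference point here. For the measured compounds named here, in an assay on isolated protein for displacement of a labelled ligand from melanin-concentrating hormone receptor 1 (Homo sapiens) (on this read-out higher numbers stand for weaker inhibition and lower numbers for stronger inhibition), compound 1 gives 4 nM, the lowest of the three numbers measured so far; compound 3 `CC(=O)NC1CCN(c2ccc3cc(NC(=O)CCc4ccc(C(F)(F)F)cc4)ccc3n2)C1` with 5 nM sits within the usual scatter of that number, while compound 2 `CN(C)c1ccc2cc(NC(=O)CCc3ccc(C(F)(F)F)cc3)ccc2n1` with 13 nM lies further off. The steps that alter this same position on the shared core read a 3.3-fold higher number from compound 1 to compound 2 (0.51 log units; beyond the scatter) and a 1.3-fold higher number from compound 1 to compound 3 (0.10 log units; within the scatter), and between those two compounds the step is a 2.6-fold lower number from compound 2 to compound 3 (0.41 log units; beyond the scatter).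

Compound 4 `O=C(CCc1ccc(C(F)(F)F)cc1)Nc1ccc2nc(N3CCC4(CCNC4)C3)ccc2c1` has not yet been measured. It differs from compound 1 as follows: a group of 9 heavy atoms (7 carbon, 2 nitrogen; 2 five-membered non-aromatic rings with 1 hetero atom each) in place of a group of 4 heavy atoms (3 carbon, 1 nitrogen; one four-membered non-aromatic ring with 1 hetero atom), on an aromatic carbon. The step most relevant to this change is the one to a five-membered ring, since a 1.3-fold higher number from compound 1 to compound 3 (0.10 log units; within the scatter) shows a larger ring-based group at this position leaves the number essentially unchanged. Going by the values given here, the only step beyond the scatter, a 3.3-fold higher number from compound 1 to compound 2 (0.51 log units; beyond the scatter), belongs to a group without a ring and runs toward weaker inhibition. The step to compound 4 is therefore expected to be small, a 1.5-fold higher number from compound 1 to compound 4 (0.18 log units; within the scatter). For compound 4 the estimated value in this assay is 6 nM, with a range from 2 nM to 20 nM.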

Compound 4, half-maximal inhibitory concentration: 0.5 nM
Beside the measured number, compound 4's estimate is 12-fold (1.08 log units) above it; the whole stated range lies above it.
By their numbers in this assay, from the lowest: compound 4; then compounds 1 and 3 (each within the scatter of the next); then compound 2.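

Up to now, each group tried at this position left the number within the scatter of compound 1 or above it, so the azetidin-1-yl group looked hard to improve on. The two-ring group changes that, with an 8.0-fold lower number from compound 1 to compound 4 (0.90 log units; beyond the scatter) in this assay and a clear gain over the azetidine. Heavy-atom count alone does not follow the number, as the acetamidopyrrolidine group of compound 3 is just as large yet there is a 10-fold lower number from compound 3 to compound 4 (1.00 log units; beyond the scatter) and, from the ringless group, a 26-fold lower number from compound 2 to compound 4 (1.41 log units; beyond the scatter) as the widest gap; nothing measured here explains these steps.

Still open, from the compounds shown here alone, is which part of the new group matters: the second ring nitrogen with its hydrogen, or the two rings themselves. An oxygen in that nitrogen's place, or a methyl on it, would separate the two.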